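From 3-bromophenyl to 4-bromophenyl

The source may hold more compounds than are shown below. What is called first, only, known or untested is meant among the compounds shown, and "the series" means these compounds.

In a functional assay on U-87MG ATCC cells for antiproliferative activity against U-87 MG (Homo sapiens), read by MTT assay, with a stated time of 48 h (a higher number here means a weaker inhibitor, a lower number a stronger inhibitor), compound 1 `C#CCOC(=O)/C(C)=C/CC/C(C)=C/CC/C(C)=C/CC[C@@H]1[C@@]2(C)CCC(=O)C(C)(C)[C@H]2CC[C@@]1(C)O` gives > 150000 nM as a limit of the assay and not as a number. In this assay compound 2 `C/C(=C\CC/C(C)=C/CC[C@@H]1[C@@]2(C)CCC(=O)C(C)(C)[C@H]2CC[C@@]1(C)O)CC/C=C(\C)C(=O)OCc1cn(-c2cccc([N+](=O)[O-])c2)nn1` gives 134000 nM while compound 3 `C/C(=C\CC/C(C)=C/CC[C@@H]1[C@@]2(C)CCC(=O)C(C)(C)[C@H]2CC[C@@]1(C)O)CC/C=C(\C)C(=O)OCc1cn(-c2cccc(Br)c2)nn1` gives 8750000 nM as the highest of the numbers shown. The passage a step that the limit leaves unreadable from compound 1 to compound 3 offers no size to work from. Compound 4 `C/C(=C\CC/C(C)=C/CC[C@@H]1[C@@]2(C)CCC(=O)C(C)(C)[C@H]2CC[C@@]1(C)O)CC/C=C(\C)C(=O)OCc1cn(-c2ccc(Br)cc2)nn1` differs from compound 3 by 4-bromophenyl in place of 3-bromophenyl on an aromatic nitrogen and so carries 4-bromophenyl in place of 3-bromophenyl on an aromatic nitrogen. Going by the values given here, no measured pair moves the bromo group around the phenyl group in this way, so the size of this change cannot be read directly. The nearest evidence is a 65-fold higher number from compound 2 to compound 3 (1.81 log units; beyond the scatter) with bromo in place of nitro on an aromatic carbon, which shows that one change on the phenyl group went with a large shift in this pair. Among the compounds with values here, with compound 2 at 134000 nM as the only other true number, a lower number than that of compound 3 is expected, though with wide uncertainty. The expected step is a 22-fold lower number from compound 3 to compound 4 (1.34 log units; beyond the scatter) and it remains only an estimate. For compound 4 the estimated value is 400000 nM within an expected range from 50000 nM to 8000000 nM in this assay until a measurement settles it.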

Compound 4, half-maximal inhibitory concentration: > 150000 nM
Compound 4 gave a limit, no number; the forecaster's own chance of this, stated with the estimate: 20%; the middle value is on the limit's open side.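

Compound 4 shows that 4-bromophenyl on the aromatic nitrogen gives only a limit in this assay, not a number, and compound 1 also gives only a limit there: the limit of > 150000 nM in this assay, at which 2 of the 4 values shown sit.
The steps linking compound 4 to compound 3 and to compound 1 cannot be read, so moving the bromo group from 3-bromophenyl to 4-bromophenyl has no measurable size here. Going by these compounds alone, the one readable step is an at least 1.1-fold higher number from compound 2 to compound 4 (0.04 log units; that floor lies within the scatter), so it gives only a floor for 4-bromophenyl in place of 3-nitrophenyl and sets no order between the two groups.

The compounds shown leave open whether 4-nitrophenyl would give a number in this assay, which would show whether the nitro group responds to this position as the bromo group might. They also leave open whether an amine or a carboxylic acid on the phenyl group, or a longer chain in its place, would give a readable value on the shared core.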